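A few compounds are considered here, and "the series" means these few. Any claim that something is new, unique, unknown or untested is made for them only; others in the source may bear on it.

In a physicochemical assay for solubility, read by HPLC, measured as thermodynamic solubility, with a stated time of 4 h, at pH 6.8 (on this read-out higher numbers stand for higher solubility and lower numbers for lower solubility), compound 1 `Cc1ccc(C)c(Oc2ccc3nc(COc4cccc(C(=O)O)c4)n(C)c3c2)n1` gives 85 ug/mL and compound 2 `Cc1cnc(Oc2ccc3nc(COc4cccc(C(=O)O)c4)n(C)c3c2)c(F)c1` gives 9.2 ug/mL, the lower of the two numbers; the step of a 9.2-fold lower number from compound 1 to compound 2 (0.97 log units; beyond the scatter) is the only one measured. Compound 3 `Cc1cc(F)cnc1Oc1ccc2nc(COc3cccc(C(=O)O)c3)n(C)c2c1` differs from compound 2 by 5-fluoro-3-methylpyridin-2-yl in place of 3-fluoro-5-methylpyridin-2-yl on an oxygen on an aromatic ring. For the measured compounds named here, no measured step moves the fluorine and methyl around the same ring, and the only step on record exchanges one substituent pair for another, so it gives no direct guide. For compound 3 the step of a 1.3-fold higher number from compound 2 to compound 3 (0.12 log units; within the scatter) is expected to stay within the scatter. Compound 3 is therefore estimated at 12 ug/mL, in the range 4 ug/mL to 35 ug/mL.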

Compound 3, solubility: 14 ug/mL
For compound 3 the middle estimate is 1.2-fold (0.07 log units) below the measured one; low and high end bracket the measured number.
By their numbers in this assay, from the lowest: compounds 2 and 3 (each within the scatter of the next); then compound 1.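

In this assay, the step is a 1.5-fold higher number from compound 2 to compound 3 (0.18 log units; within the scatter), so with the same atoms joined differently, 5-fluoro-3-methylpyridin-2-yl and 3-fluoro-5-methylpyridin-2-yl are not told apart at this place. Set against 3,6-dimethylpyridin-2-yl, the step is a 6.1-fold lower number from compound 1 to compound 3 (0.78 log units; beyond the scatter), so both fluoro-methyl groups now stand apart from the dimethyl group of compound 1. No measurement bears on the reason for either step.

On these data alone, whether that gap follows from the fluorine or from the placing of the methyl groups remains open. As far as these compounds go, how an amine or a methoxy group on this ring would read also remains open.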